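Working notes on compounds 1 to 4

The source may report more compounds than this note shows. Statements on the series, on what has been measured and on what is new or still open speak of the compounds shown alone.

Measured in an assay for binding affinity to 17-beta-hydroxysteroid dehydrogenase type 1 (Homo sapiens), with a stated time of 20 min, tested at 1 uM; on this read-out lower numbers stand for less inhibition and higher numbers for more inhibition at the one concentration tested (going by the name of the read-out):
compound 1 `Oc1cccc2cc(-c3ccccc3)ccc12`: < 10%
compound 2 `CS(=O)(=O)Nc1ccc(-c2ccc(CO)cc2)cc1`: < 10%
compound 3 `Cc1cccc(S(=O)(=O)Nc2ccc(-c3ccc(CO)cc3)cc2)c1`: < 10%

The value of compound 1 is a limit of the assay, not a number. The value of compound 2 is likewise a limit. The value of compound 3 is also a limit. Among the measured compounds shown here, the one step between measured compounds that differ in one place, a step that the two limits leave unreadable from compound 2 to compound 3, therefore cannot be read. Compound 2 stands at the limit, and so do the other two values shown, because of the limit of < 10% in this assay, at which 3 of the 3 values shown sit.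

Compound 4 `CS(=O)(=O)Nc1ccc(-c2ccc(O)cc2)cc1` has not been measured in this assay. Its difference from compound 2 is hydroxy in place of hydroxymethyl on an aromatic carbon. For the measured compounds named here, no measured step pairs a hydroxymethyl with a hydroxy, so nothing measured bears directly on this change. Compound 1, which also carries a hydroxy, gives only a limit in this assay.

With every value shown sitting at the limit and no readable step in the set, the step that the limit leaves unreadable from compound 2 to compound 4 is expected to show nothing beyond the scatter, and compound 4 is most likely to return a limit again. Compound 4 is therefore estimated at 5%, in the range 0% to 15%.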

Compound 4, a percentage reported as inhibition, at one concentration (the size of the read-out at that concentration, not a potency): < 10%
Compound 4 gave a limit, no number (the forecaster's own chance of this, stated with the estimate: 75%); the middle value does not contradict the limit.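

Among the compounds shown here, compound 4 also gives only a limit, so no step from compound 2 to compound 4 can be read, because both values are limits: the limit of < 10% in this assay, at which 4 of the 4 values shown sit.

Left open is whether hydroxy in place of hydroxymethyl on an aromatic carbon alters inhibition in this assay at all, and which change to the shared core would give a readable number there.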